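Aryl swap on a shared core and microsomal clearance

The source may hold more compounds than are shown below. What is called first, only, known or untested is meant among the compounds shown, and "the series" means these compounds.

Measured compounds in an ADME assay (liver) for metabolic stability, with Liver microsome (Homo sapiens) as the target, using microsomes and NADPH, with a stated time of 30 min, tested at 1 uM; on this read-out lower numbers stand for slow clearance and higher numbers for fast clearance:
- compound 1 `Nc1ccc(S(=O)(=O)N2CCN(c3ncc(C(O)(C(F)(F)F)C(F)(F)F)cc3C#CCCO)CC2)cn1`; the value of compound 1 is a limit of the assay, < 14 mL.min-1.g-1.
- compound 2 `Cn1cc(-c2cc(C(O)(C(F)(F)F)C(F)(F)F)cnc2N2CCN(S(=O)(=O)c3ccc(N)nc3)CC2)cn1`; compound 2 gives 19 mL.min-1.g-1.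
- compound 3 `COc1ccc(-c2cc(C(O)(C(F)(F)F)C(F)(F)F)cnc2N2CCN(S(=O)(=O)c3ccc(N)nc3)CC2)cn1`; compound 3 gives 25 mL.min-1.g-1.

Of the two plain numbers compound 2 sits at one end, with compound 3 nearest; the step of a 1.3-fold higher number from compound 2 to compound 3 (0.12 log units; within the scatter) is within the scatter. Compound 4 `COc1cncc(-c2cc(C(O)(C(F)(F)F)C(F)(F)F)cnc2N2CCN(S(=O)(=O)c3ccc(N)nc3)CC2)c1` differs from compound 2 by 5-methoxypyridin-3-yl in place of 1-methyl-1H-pyrazol-4-yl on an aromatic carbon. The most relevant measured step is a 1.3-fold higher number from compound 2 to compound 3 (0.12 log units; within the scatter), where a methoxy-bearing six-membered ring also replaced the pyrazole and the number barely moved; the steps of an at least 1.3-fold higher number from compound 1 to compound 2 (0.13 log units; that floor lies within the scatter) and an at least 1.7-fold higher number from compound 1 to compound 3 (0.25 log units; that floor lies within the scatter) start from a limit and stay small. In this assay compound 4 is therefore expected to show no step beyond the scatter, a 1.3-fold higher number from compound 2 to compound 4 (0.12 log units; within the scatter). The estimate for compound 4 is 25 mL.min-1.g-1, with a range from 14 mL.min-1.g-1 to 45 mL.min-1.g-1.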

Compound 4, intrinsic clearance in microsomes: 44 mL.min-1.g-1
Estimate against measurement, compound 4: 1.8-fold (0.25 log units) below, and the stated range covers the measured number.
By their numbers in this assay, from the lowest: compounds 2, 3 and 4 (each within the scatter of the next, the first and the last beyond it). At a limit, below all of these: compound 1.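

In this assay, for the compounds shown here, a 2.3-fold higher number from compound 2 to compound 4 (0.36 log units; beyond the scatter) is the first step at this aromatic carbon that clearly exceeds the scatter, so the ring placed here can change clearance. Replacing 6-methoxypyridin-3-yl with 5-methoxypyridin-3-yl gives a 1.8-fold higher number from compound 3 to compound 4 (0.25 log units; within the scatter), so moving the methoxy group has no resolved effect. Replacing 4-hydroxybut-1-yn-1-yl gives an at least 3.1-fold higher number from compound 1 to compound 4 (0.49 log units; beyond the scatter), which is only a floor, as it starts from a limit of the assay: the limit of < 14 mL.min-1.g-1 in this assay, at which 1 of the 4 values shown sits.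

The compounds shown do not reveal what drives the rise. A plain pyridin-3-yl ring, or a pyridine carrying an amine instead of methoxy, could help separate the roles of the ring and its substituent.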